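A few compounds are considered here, and "the series" means these few. Any claim that something is new, unique, unknown or untested is made for them only; others in the source may bear on it.

Measured compounds in a functional assay (HSMC cells, Homo sapiens) for antiproliferative activity, with a stated time of 72 h; a higher number here means a weaker inhibitor, a lower number a stronger inhibitor:

compound 1 `COC(=O)[C@H](CCSC)NC(=O)c1ccc(OC[C@H]2COc3ccccc3O2)cc1-c1ccccc1OC`: 230000 nM
compound 2 `COC(=O)CNC(=O)c1ccc(OC[C@H]2COc3ccccc3O2)cc1-c1ccccc1OC`: 71000 nM
compound 3 `COC(=O)[C@H](CCSC)NC(=O)c1ccc(C(=O)NC[C@H]2COc3ccccc3O2)cc1-c1ccccc1C`: 87000 nM

Compound 1 and compound 2 share a core and differ in one place: hydrogen in place of 2-(methylsulfanyl)ethyl on a saturated chain carbon bound to an amide-type nitrogen and a carbonyl carbon. This change gave a 3.2-fold lower number from compound 1 to compound 2 (0.51 log units; beyond the scatter), a shift beyond the scatter, so the change as such reads as a real gain in this assay for that core.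

Compound 3 carries a different core. How the core of compound 3 differs from the core of compound 1 is not broken down here. Compound 3 sits close to compound 2, the two values being within the scatter of each other, while the gap between compound 3 and compound 1 is beyond the scatter, with compound 1 giving the higher number.

Compound 4 `COC(=O)CNC(=O)c1ccc(C(=O)NC[C@H]2COc3ccccc3O2)cc1-c1ccccc1C` is not yet measured. It differs from compound 3 by hydrogen in place of 2-(methylsulfanyl)ethyl on a saturated chain carbon bound to an amide-type nitrogen and a carbonyl carbon, which is the same change as that from compound 1 to compound 2, made at the same kind of place on the other core. Among the measured compounds shown here, on the one earlier example, the change is expected to move compound 4 by a 3.1-fold lower number from compound 3 to compound 4 (0.49 log units; beyond the scatter), a step of about the size seen from compound 1 to compound 2, because the earlier change gave a 3.2-fold lower number from compound 1 to compound 2 (0.51 log units; beyond the scatter). For the measured compounds named here, only one example supports this, and the two cores are not the same, so the range is kept wide. Compound 4 is therefore estimated at 28000 nM, expected to fall between 9000 nM and 80000 nM.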

Compound 4, half-maximal inhibitory concentration: 113000 nM
Estimate against measurement, compound 4: 4.0-fold (0.61 log units) below, outside the stated range (above it).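

In this assay, replacing 2-(methylsulfanyl)ethyl with hydrogen on the saturated chain carbon of the core of compound 3 gave a 1.3-fold higher number from compound 3 to compound 4 (0.11 log units; within the scatter), so no real shift can be read for this pair. Among the compounds shown here, the gain seen on the core of compound 1 therefore did not carry over to the core of compound 3, and the size of this step depends on the core in these two pairs: the same change on two cores in this assay, a 3.2-fold lower number (0.51 log units; beyond the scatter) from compound 1 to compound 2 and a 1.3-fold higher number (0.11 log units; within the scatter) from compound 3 to compound 4, 4.2-fold (0.62 log units) apart, beyond the scatter of two such steps This shows that a step read on one core cannot be assumed to hold on the other, but with only two pairs it gives no general rule for the change, does not identify which feature of the cores separates the two outcomes, and does not show that the change is without effect on every related core.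

Still open, as far as these compounds go, is whether a methyl group or a longer unbranched alkyl chain at this carbon would separate the two cores in the same way as hydrogen and 2-(methylsulfanyl)ethyl do. Also open, from the compounds shown here alone, is how a carboxylic acid in place of the methoxycarbonyl group would read on each core in this assay.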